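Methoxy Added to the Thiazole Aryl of Compound 1

The source may hold more compounds than are shown below. What is called first, only, known or untested is meant among the compounds shown, and "the series" means these compounds.

Measured compounds:
Compound 1 `COc1ccc(-c2nc(SCC(=O)c3sc(-c4ccccc4)nc3C)nc(N)c2C#N)cc1`: 68.8%
Compound 2 `Cc1nc(-c2ccccc2)sc1C(=O)CSc1nc(-c2cccc(Cl)c2)c(C#N)c(=O)[nH]1`: 86.9%
Compound 3 `Cc1nc(-c2ccccc2)sc1C(=O)CSc1nc(N)c(C#N)c(-c2ccccc2)n1`: 103%

In a functional assay on U-87MG ATCC cells for antiproliferative activity against U-87 MG (Homo sapiens), read by MTT assay, with a stated time of 48 h, tested at 5 uM (a higher number here means a weaker effect of the compound at the concentration tested, a lower number a stronger effect), compound 1 gives 68.8%, the lowest of the three numbers. Compound 2 stands beyond the scatter above it, and compound 3 further still, a gap described by a number 34.2 percentage points higher from compound 1 to compound 3 (beyond the scatter), where the change is hydrogen in place of methoxy on an aromatic carbon.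

Compound 4 `COc1ccc(-c2nc(C)c(C(=O)CSc3nc(N)c(C#N)c(-c4ccc(OC)cc4)n3)s2)cc1` has not been measured in this assay. It differs from compound 1 by methoxy in place of hydrogen on an aromatic carbon. For the measured compounds named here, the only measured step that bears on it is the one from compound 1 to compound 3, which concerns a methoxy on the other aromatic ring of the shared core and was large. Nothing in the three measured compounds addresses a methoxy on the phenyl attached to the thiazole, so the size of the step is uncertain. A step of a number 4.8 percentage points lower from compound 1 to compound 4 (within the scatter) in this assay is expected, no larger than the scatter. Compound 4 is therefore estimated at 64%, within the range 40% to 88%.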

Compound 4, a percentage reported as activity, at one concentration (the size of the read-out at that concentration, not a potency): 35.6%
The estimate for compound 4 lay 28.4 percentage points above the measured number; the measured number lies below the stated range.
By their numbers in this assay, from the lowest: compound 4; then compound 1; then compound 2; then compound 3.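

In this assay, for the compounds shown here, replacing hydrogen with methoxy on the unsubstituted phenyl of compound 1 gives a large step, a number 33.2 percentage points lower from compound 1 to compound 4 (beyond the scatter), so this position, which the earlier compounds left unvaried, clearly affects the read-out. The earlier step, a number 34.2 percentage points higher from compound 1 to compound 3 (beyond the scatter), had linked the loss of a methoxy on the other aromatic ring to a weaker effect, and the new step now links a methoxy gain on this phenyl to a stronger one, so across these two steps a methoxy goes with the stronger effect on both rings. Nothing shown here explains the size of this step.

On these data alone, it remains open whether an ethoxy group, a hydroxy group or a chlorine atom at this same place would act as methoxy does. As far as these compounds go, it is also open whether methoxy here would give a similar step with plain phenyl on the other ring.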